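This account rests on a few compounds, and the source may have more. Where it says the series, first, only, none or still open, it means among the compounds named here.

Working notes on the series. Within the data shown here, compound 1 `CCCCCCCC/C=C\CCCCCCC(=O)c1ncc(-c2ccccn2)o1` is the reference point: in an assay on isolated protein for inhibition of Fatty-acid amide hydrolase 1 (Homo sapiens) (a lower number here means a stronger inhibitor, a higher number a weaker inhibitor), compound 1 gives 18 nM, the only plain number so far. Compound 2 `CCCCCCCC/C=C\CCCCCCC(=O)c1nc2c(C)cccc2o1` reaches only a limit of the assay, > 100000 nM, so it yields no number to set against compound 1; the position of that limit is the limit of > 100000 nM in this assay, at which 1 of the 2 values shown sits. Among the measured compounds shown here, no step between two measured compounds with a single point of difference is available, so the size of any change has to be estimated rather than read off.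

Compound 3 `CCCCCCCC/C=C\CCCCCCC(=O)c1ncc(-c2cccnc2)o1` is the next point. It differs from compound 1 by pyridin-3-yl in place of pyridin-2-yl on an aromatic carbon. In this assay the expected step from compound 1 to compound 3 is a modest loss, likely at the edge of the scatter rather than far beyond it, estimated as a 3.3-fold higher number from compound 1 to compound 3 (0.52 log units; beyond the scatter). For compound 3 the expected inhibition constant is 60 nM, within a range of 15 nM to 250 nM.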

Compound 3, inhibition constant: 61 nM
Beside the measured number, compound 3's estimate is 1.0-fold (0.01 log units) below it; the measured number falls inside the stated range.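

Among these compounds, this is the first step that can be read as a number: with the same atoms and the same counts, pyridin-3-yl in place of pyridin-2-yl gives a 3.4-fold higher number from compound 1 to compound 3 (0.53 log units; beyond the scatter) in this assay. The aromatic carbon next to the ring oxygen is therefore sensitive to how the pyridine ring is joined to it, though only modestly, since this change alone costs far less than the full range of the assay. Nothing measured here speaks to the origin of this step.

Open, as far as these compounds go, is how pyridin-4-yl, a plain phenyl or an amine on this same aromatic carbon would compare with compound 1. Also open, from the compounds shown here alone, is whether the step would keep its size with a fully saturated chain in place of the unsaturated one.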